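The source may hold more compounds than are shown below. What is called first, only, known or untested is meant among the compounds shown, and "the series" means these compounds.

Series notes. Compound 1 `CN1C(=O)[C@H](NC(=O)c2n[nH]c(Cc3ccccc3)n2)COc2ncccc21` and compound 3 `CN1C(=S)[C@@H](NC(=O)c2n[nH]c(Cc3ccccc3)n2)COc2ncccc21` share much of their skeleton, but the difference between the two cores is not broken down here. In a functional assay on HT-29 cells (Homo sapiens) for inhibition, read by luminescence and CellTiter-Glo, with a stated time of 10 h (on this read-out lower numbers stand for an effect already at smaller amounts and higher numbers for an effect only at larger amounts of compound), compound 1 gives only a limit, > 10000 nM. Compound 3 likewise gives only a limit in this assay, > 10000 nM. Compound 2 `Cc1ccc2c(n1)OC[C@@H](NC(=O)c1n[nH]c(Cc3ccccc3)n1)C(=O)N2C` carries methyl in place of hydrogen on an aromatic carbon on the core of compound 1, and in this assay compound 2 gives 6500 nM; the step is an at least 1.5-fold lower number from compound 1 to compound 2 (0.18 log units; that floor lies within the scatter), which rests on the limit of > 10000 nM in this assay, at which 2 of the 3 values shown sit, and so cannot be sized further.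

Compound 4 `Cc1cnc2c(c1)N(C)C(=S)[C@@H](NC(=O)c1n[nH]c(Cc3ccccc3)n1)CO2` is the still unmeasured partner of compound 3, made by methyl in place of hydrogen on an aromatic carbon. This is the same kind of change as from compound 1 to compound 2, though the two places are not identical: in the change on the core of compound 1 the methyl sits next to the ring nitrogen, whereas in the change on the core of compound 3 it sits two atoms from the ring nitrogen. Given that compound 3 itself only reaches the limit, the step from compound 3 to compound 4 is expected to be an at least 1.2-fold lower number from compound 3 to compound 4 (0.09 log units; that floor lies within the scatter), a modest move at best, with a real chance that this assay again returns only a limit. For compound 4 in this assay the expected value is 8000 nM, estimated to fall between 3000 nM and 30000 nM.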

Compound 4, half-maximal effective concentration: 144 nM
Compound 4: the middle estimate sits 56-fold (1.74 log units) above what was measured; the measured number lies below the stated range.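

In this assay, methyl in place of hydrogen on an aromatic carbon, here two atoms from the ring nitrogen, gives a large step: an at least 69-fold lower number from compound 3 to compound 4 (1.84 log units; beyond the scatter). This shows that so small a change can carry a large gain on at least one core of the series, but it does not establish that the gain transfers from one core to another, as the comparison with the earlier step remains unresolved: the same change on two cores in this assay, an at least 1.5-fold lower number (0.18 log units; that floor lies within the scatter) from compound 1 to compound 2 and an at least 69-fold lower number (1.84 log units; beyond the scatter) from compound 3 to compound 4; the limit leaves it open whether they differ. Neither step has a known full size, and the methyl does not occupy the same place on the two cores, so these two pairs cannot show whether the core, the place of the methyl or both govern the outcome, and the true sizes stay hidden behind the assay limit: the limit of > 10000 nM in this assay, at which 2 of the 4 values shown sit.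

The compounds shown leave open whether methyl on the core of compound 1 would give a similar step at the place it occupies in compound 4, and the reverse on the core of compound 3. They also leave open whether ethyl, methoxy or a chlorine atom at the same aromatic carbon would match methyl in this assay.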